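Compound 1 and a Nitrile-Bearing Analogue

A few compounds are considered here, and "the series" means these few. Any claim that something is new, unique, unknown or untested is made for them only; others in the source may bear on it.

Among the measured compounds shown here, compound 1 `O=c1oc2ccccc2c(O)c1C(c1ccc(F)c(F)c1)c1c(O)c2ccccc2oc1=O` gives 47.9 ug/mL in a functional assay on 4T1 cells (Mus musculus) for antiproliferative activity, read by MTT assay, with a stated time of 48 h (a lower number here means a stronger inhibitor, a higher number a weaker inhibitor), the lowest of the two numbers measured so far. Compound 3 `N#CC1=C(N)OC2=C(C(=O)CC2)C1c1ccc(Cl)cc1Cl` gives 127 ug/mL in this assay, a value that stands beyond the scatter above compound 1. Compound 2 `CC1(C)CC(=O)C2=C(C1)OC(N)=C(C#N)C2c1cc(C(F)(F)F)cc(C(F)(F)F)c1` gives > 300 ug/mL in this assay, a limit rather than a number, the same as the limit of > 300 ug/mL in this assay, at which 1 of the 3 values shown sits. Compound 4 `N#Cc1ccc(C(c2c(O)c3ccccc3oc2=O)c2c(O)c3ccccc3oc2=O)cc1` differs from compound 1 in one place: 4-cyanophenyl in place of 3,4-difluorophenyl on a saturated chain carbon bound to two aromatic carbons. For the measured compounds named here, no measured pair shows this change, so its direction remains open; a step of little size, within the scatter, is expected a 1.1-fold lower number from compound 1 to compound 4 (0.03 log units; within the scatter). Compound 4 is therefore estimated at 45 ug/mL, with a likely range from 20 ug/mL to 110 ug/mL.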

Compound 4, half-maximal inhibitory concentration: 51.5 ug/mL
Compound 4: middle estimate off by 1.1-fold (0.06 log units), on the low side; measured number inside the range.
By their numbers in this assay, from the lowest: compounds 1 and 4 (each within the scatter of the next); then compound 3. At a limit, above all of these: compound 2.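

In this assay, putting 4-cyanophenyl in place of 3,4-difluorophenyl on a saturated chain carbon bound to two aromatic carbons gives a 1.1-fold higher number from compound 1 to compound 4 (0.03 log units; within the scatter). Among the compounds shown here, this is the first pair of compounds differing in one place, and it shows that this position accepts a nitrile-bearing ring in place of the fluorinated one with no readable change in the number. Nothing measured here bears on why the two groups read alike. From the compounds shown here alone, whether an amine or a carboxylic acid on this ring would read the same remains open. So does the effect of a longer chain in place of the ring.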